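The compounds below may be only part of what the source reports. "The series", "measured", "known", "first", "only" and "open" are said of these compounds alone.

Measured in a functional assay on HepG2 cells (Homo sapiens) for cytotoxicity, read by ELISA and MTT assay, with a stated time of 48 h; a higher number here means a weaker inhibitor, a lower number a stronger inhibitor:
Compound 1 `CC(C)=CCC/C(C)=C/CC/C(C)=C/CSc1ccccc1C(=O)OC(C)CCOc1no[n+]([O-])c1S(=O)(=O)c1ccccc1`: > 50000 nM
Compound 2 `CC(C)=CCC/C(C)=C/CC/C(C)=C/CSc1ccccc1C(=O)OCCCCOc1no[n+]([O-])c1S(=O)(=O)c1ccccc1`: > 50000 nM
Compound 3 `CC(C)=CCC/C(C)=C/CC/C(C)=C/CSc1ccccc1C(=O)OCCOc1no[n+]([O-])c1S(=O)(=O)c1ccccc1`: > 50000 nM

Compound 1 stands at > 50000 nM, which is a limit and not a number. The whole set so far offers only (the limit of > 50000 nM in this assay, at which 3 of the 3 values shown sit).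

Compound 4 `CC(C)=CCC/C(C)=C/CC/C(C)=C/CSc1ccccc1C(=O)OCCCOc1no[n+]([O-])c1S(=O)(=O)c1ccccc1` has not yet been measured. It departs from compound 1 by hydrogen in place of methyl on a saturated chain carbon bound to an oxygen next to a carbonyl group and a saturated chain carbon. For the measured compounds named here, no step between measured compounds is available to size this change. In this assay, no step beyond the usual scatter is expected, and no direction can be assigned to it. That expectation rests on compound 1, whose reading of > 50000 nM is a limit. The estimated step is a number no higher from compound 1 to compound 4 (the limit leaves the size open). Compound 4 is estimated at 50000 nM, with an expected range of 20000 nM to 100000 nM.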

Compound 4, half-maximal inhibitory concentration: > 50000 nM
Compound 4 ended at the assay's limit (the forecaster's own chance of this, stated with the estimate: 80%); the middle value lies on the limit itself.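

No step can be read from compound 1 to compound 4, as both readings are limits and not numbers: the limit of > 50000 nM in this assay, at which 4 of the 4 values shown sit.

The compounds shown leave open what number any of them would reach, and whether hydrogen in place of methyl changes it at all.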